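Compound 3 to compound 4: bromo replaces the sulfamoyl group

The source may report more compounds than this note shows. Statements on the series, on what has been measured and on what is new or still open speak of the compounds shown alone.

Compound 3 `CC1(C)N=C(N)N=C(N)N1c1cccc(S(N)(=O)=O)c1` gives 5.61 in a functional assay on L5178Y cells (Mus musculus) for inhibition (on this read-out higher numbers stand for higher potency (the scale is a negative logarithm) and lower numbers for lower potency), the lowest of the three numbers in hand. Compound 1 `CC1(C)N=C(N)N=C(N)N1c1cccc(C(O)c2ccccc2)c1` gives 6.41 and compound 2 `CC1(C)N=C(N)N=C(N)N1c1cccc(C2CCCCC2)c1` gives 7.97 in this assay, so compound 3 trails both, by a number 0.80 log units lower from compound 1 to compound 3 (beyond the scatter) and by a number 2.36 log units lower from compound 2 to compound 3 (beyond the scatter), each beyond the scatter.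

Compound 4 `CC1(C)N=C(N)N=C(N)N1c1cccc(Br)c1` is not yet measured; it differs from compound 3 in one place: bromo in place of sulfamoyl on an aromatic carbon. The two measured steps that bear on this are the ones ending at sulfamoyl, a number 0.80 log units lower from compound 1 to compound 3 (beyond the scatter) and a number 2.36 log units lower from compound 2 to compound 3 (beyond the scatter): both times sulfamoyl arrived and the number fell, once modestly and once by a large margin. Bromo, a single heavy atom with neither donor nor acceptor, sits closer in kind to cyclohexyl than to sulfamoyl, so an upward step is expected when sulfamoyl leaves. Because the fall was a number 2.36 log units lower from compound 2 to compound 3 (beyond the scatter) for the largest group, the expected rise is estimated at a number 1.59 log units higher from compound 3 to compound 4 (beyond the scatter), somewhat less than a full reversal. Compound 4 is therefore expected to give 7.2 in this assay, within a range of 6.5 to 7.9.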

Compound 4, logarithm of the reciprocal of the active concentration, log(1/C): 8.42
Compound 4: the middle estimate sits 1.22 log units below what was measured; measured number outside the range, above it.
By their numbers in this assay, from the lowest: compound 3; then compound 1; then compound 2; then compound 4.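

On this aromatic carbon, one bromine atom is enough to give the highest number of the four in this assay: the step of a number 0.45 log units higher from compound 2 to compound 4 (beyond the scatter) shows that the cyclohexyl ring is not needed for high potency, and the step of a number 2.01 log units higher from compound 1 to compound 4 (beyond the scatter) shows the same for the hydroxy(phenyl)methyl group. The step of a number 2.81 log units higher from compound 3 to compound 4 (beyond the scatter) also shows how much separates the two ends of this set at a single position, so the group here, with the shared core unchanged, can carry the read-out across a wide span. Nothing among the data available accounts for why bromo stands at the top.

Going by these compounds, it remains open whether chloro, iodo or an amine on the same aromatic carbon would match bromo. On these data alone, it is also open whether bromo would hold its number on a different carbon of the ring.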